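This account rests on a few compounds, and the source may have more. Where it says the series, first, only, none or still open, it means among the compounds named here.

Compound 1, `COCCOc1no[n+]([O-])c1S(=O)(=O)c1ccccc1`, gives 3910 nM in a functional assay on SK-OV-3 cells (Homo sapiens) for antiproliferative activity, read by MTT assay, with a stated time of 48 h; on this read-out higher numbers stand for weaker inhibition and lower numbers for stronger inhibition.
Compound 2, `COc1cc(OCCOc2no[n+]([O-])c2S(=O)(=O)c2ccccc2)ccc1C(=O)/C=C/c1ccc(F)cc1`, gives 25 nM in this assay.
Compound 3, `Cc1c(Cc2ccc(F)cc2)c(=O)oc2cc(OCCOc3no[n+]([O-])c3S(=O)(=O)c3ccccc3)ccc12`, gives 8.3 nM in this assay.

Among the three measured compounds, compound 3 has the lowest number. Compound 2 stands nearest to it, and that gap lies beyond the scatter; compound 1 stands furthest away, with a gap far beyond the scatter. Compound 3 is therefore the strongest inhibitor of the three in this assay, and it is the point from which the next step is taken.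

Compound 4, `CNS(=O)(=O)Nc1cccc(Cc2c(C)c3ccc(OCCOc4no[n+]([O-])c4S(=O)(=O)c4ccccc4)cc3oc2=O)c1`, has not yet been measured. It differs from compound 3 in one place only: 3-((methylsulfamoyl)amino)phenyl in place of 4-fluorophenyl on a saturated chain carbon bound to an aromatic carbon. The shared core of compound 3 and compound 4 is left untouched. Among the measured compounds shown here, no pair of measured compounds differs in a single place, so there is no precedent in this set from which the size of the step could be read.

With the core of the most potent compound kept and only the pendant aryl group exchanged, the expectation is a small step in this assay, with a slight lean towards a higher number, of a size that may well stay within the scatter. Compound 4 is expected to give about 14 nM, in a range from 3.5 nM to 60 nM. The estimated step is a 1.7-fold higher number from compound 3 to compound 4 (0.23 log units; within the scatter).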

Compound 4, half-maximal inhibitory concentration: 19.2 nM
Beside the measured number, compound 4's estimate is 1.4-fold (0.14 log units) below it; low and high end bracket the measured number.
By their numbers in this assay, from the lowest: compound 3; then compounds 4 and 2 (each within the scatter of the next); then compound 1.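

Among the compounds shown here, exchanging 4-fluorophenyl for 3-((methylsulfamoyl)amino)phenyl on a saturated chain carbon bound to an aromatic carbon gives, in this assay, a 2.3-fold higher number from compound 3 to compound 4 (0.36 log units; beyond the scatter), the first reading in this set of a change made in one place only. The step is modest but beyond the scatter, and compound 4 still gives 19.2 nM, so this position accepts a larger group that carries hydrogen-bond donors and acceptors, where 4-fluorophenyl has none, with only a limited loss of inhibition. Nothing available here bears on the origin of this step, which therefore stands as an observation without an explanation.

A single step cannot separate the contribution of the loss of fluorine from that of the methylsulfamoyl amino group or its place on the phenyl ring. On these data alone, it remains open whether a plain amine, a carboxylic acid or a methanesulfonamide on that phenyl ring would give a number closer to that of compound 3, and whether a longer chain between the ring and the shared core would keep this level of inhibition.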